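Replacing the chloroacetyl group of compound 3 with a urea chain

The source may hold more compounds than are shown below. What is called first, only, known or untested is meant among the compounds shown, and "the series" means these compounds.

Of the compounds shown here, three have been tested in a functional assay on MCF7 cells (Homo sapiens) for antiproliferative activity, read by sulforhodamine B assay, with a stated time of 48 h; on this read-out higher numbers stand for weaker inhibition and lower numbers for stronger inhibition. Compound 1 `CC(C)C(=O)Nc1cccc(S(=O)(=O)Oc2ccccc2C(C)C)c1` gives 13000 nM. Compound 2 `CC(C)c1ccccc1OS(=O)(=O)c1ccc(NC(=O)CCl)cc1` gives 2900 nM, and compound 3 `O=C(CCl)Nc1ccc(S(=O)(=O)Oc2ccccc2I)cc1` gives 2500 nM. On these numbers compound 3 stands lowest of the three, with compound 2 close by and compound 1 further away. Among the compounds with values here, the one single-point step among them, a 1.2-fold lower number from compound 2 to compound 3 (0.06 log units; within the scatter), concerns a change on the aromatic ring rather than on the amide.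

Compound 4 `O=C(NCCCCl)Nc1ccc(S(=O)(=O)Oc2ccccc2I)cc1` differs from compound 3 in one place: (3-chloropropyl)amino in place of chloromethyl on a carbonyl carbon. Within the data shown here, no measured step touches this part of the molecule, so no step gives a direct guide. Compound 1 and compound 2 differ in two places at once, one of them at the same carbonyl, and their values show that compound 1 gives 13000 nM while compound 2 gives 2900 nM; this only hints that changing the acyl group can matter. Compound 4 is therefore expected near 6000 nM, within 2000 nM to 20000 nM, and the expected step is a 2.4-fold higher number from compound 3 to compound 4 (0.38 log units; beyond the scatter).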

Compound 4, half-maximal inhibitory concentration: 7600 nM
For compound 4 the middle estimate is 1.3-fold (0.10 log units) below the measured one, and the stated range covers the measured number.
By their numbers in this assay, from the lowest: compounds 3 and 2 (each within the scatter of the next); then compounds 4 and 1 (each within the scatter of the next).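

Within the data shown here, until now no step had touched the group on this carbonyl carbon. Putting (3-chloropropyl)amino in place of chloromethyl gives a 3.0-fold higher number from compound 3 to compound 4 (0.48 log units; beyond the scatter), so this position does respond to change, though the step is modest and compound 4 still has a measurable value in the same range as the other compounds. The change brings in a nitrogen with its hydrogen-bond donor and a longer carbon chain together, so this one step cannot separate the two, and no measurement shown here explains the shift.

Still open, on these data alone, is how a urea carrying a plain propyl chain without chlorine, or a shorter 2-chloroethyl chain, would compare with compound 4. Also open, as far as these compounds go, is whether the same urea chain would give a similar step with isopropyl in place of iodo on the aromatic ring.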